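Plasma stability notes: removing the glycyl amide from compound 1

The source may hold more compounds than are shown below. What is called first, only, known or untested is meant among the compounds shown, and "the series" means these compounds.

Measured compounds
Compound 1 `COc1cc(NC(C)CCCN2C(=O)[C@@H](C)N(C(=O)CN)C2(C)C)c2ncccc2c1`: in an ADME assay on a cell-free system (plasma, Homo sapiens) for metabolic stability, with Plasma (Rattus norvegicus) as the target, read by HPLC (a lower number here means that the compound disappears faster, a higher number that the compound lasts longer), compound 1 gives > 3 h, a limit of the assay.
Compound 2 `COc1cc(NC(C)CCCN2C(=O)CN(C(=O)[C@@H](C)N)C2(C)C)c2ncccc2c1`: compound 2 gives > 3 h, again a limit.
Compound 3 `COc1cc(NC(C)CCCN2C(=O)CN(C(=O)[C@H](N)CC(C)C)C2(C)C)c2ncccc2c1`: compound 3 gives > 3 h, also a limit.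

Compound 1 therefore stands at the assay limit, and so do both other measured compounds; the three sit together at the limit of > 3 h in this assay, at which 3 of the 3 values shown sit. No number separates them, and no order among them can be read.

Compound 4 `COc1cc(NC(C)CCCN2C(=O)[C@@H](C)NC2(C)C)c2ncccc2c1` differs from compound 1 by hydrogen in place of (aminomethyl)carbonyl on an amine nitrogen in a ring. Going by the values given here, only one measured step touches the amide-bearing part of the core: a step that the two limits leave unreadable from compound 2 to compound 3, which both limits leave unreadable. Among the compounds with values here, no measured step removes an acyl group from the ring nitrogen, so nothing directly comparable to the change in compound 4 exists in the numbers.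

With every measured value resting at the limit, the expectation for compound 4 can only be that it remains long-lived in this assay; the step is estimated as a step that the limit leaves unreadable from compound 1 to compound 4, with no direction beyond the scatter claimed. Compound 4 is estimated at 4 h, expected between 1.5 h and 10 h, most likely reported again only as a limit.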

Compound 4, half-life in the Plasma assay: > 3 h
Compound 4 ended at the assay's limit (the forecaster's own chance of this, stated with the estimate: 75%); the middle value does not contradict the limit.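

In the Plasma assay compound 1 gives > 3 h, a limit of the assay. In the Plasma assay compound 4 gives > 3 h, also a limit. Both compounds therefore rest at a limit of the Plasma assay, so no step between them can be read there: the limit of > 3 h in the Plasma assay, at which 4 of the 4 values shown sit.

In a physicochemical assay for lipophilicity, measured as octanol-water partition (on this read-out higher numbers stand for higher lipophilicity and lower numbers for lower lipophilicity), compound 1 gives 2.54 and compound 4 gives 3.25. The compounds shown leave open how long any of them actually lasts in the Plasma assay, and whether the step in the physicochemical assay, a number 0.71 log units higher from compound 1 to compound 4 (beyond the scatter), goes with any difference in half-life.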